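This account rests on a few compounds, and the source may have more. Where it says the series, first, only, none or still open, it means among the compounds named here.

Compound 1 `COc1cccc(N2CCN(C(=O)C(C)N3C(=O)CCC3=O)CC2)c1` was examined in a functional assay on the whole organism (strain Swiss) with Mus musculus as the target, in the maximal electroshock model, with a stated time of 2 h, at a dose of 100 mg/kg by the intraperitoneal route (a higher number here means a stronger effect of the compound at the dose given, a lower number a weaker effect), where compound 1 gives 0%. Compound 2 `COCC(C(=O)N1CCN(c2cccc(C(F)(F)F)c2)CC1)N1C(=O)CCC1=O` gives 0% in this assay, so compound 1 sits level with compound 2 at the digits shown, well within the usual scatter. Compound 3 `CC(C(=O)N1CCN(c2ccccc2)CC1)N1C(=O)CCC1=O` differs from compound 1 by a single change: hydrogen in place of methoxy on an aromatic carbon. Going by the values given here, no step between two measured compounds is known here, so nothing directly shows how this change moves the read-out. The step of no change at the digits printed from compound 1 to compound 3 (within the scatter) is expected to be none beyond the scatter. Compound 3 is expected to give 0%, in a range from 0% to 10%.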

Compound 3, a percentage reported as activity, at one dose (the size of the read-out at that dose, not a potency): 0%
Estimate against measurement, compound 3: no gap at the digits printed, within the range that was stated.
By their numbers in this assay, from the lowest: compounds 1, 2 and 3 (each within the scatter of the next).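

Going by these compounds alone, replacing methoxy with hydrogen on the aromatic carbon gives no change at the digits printed from compound 1 to compound 3 (within the scatter) in this assay, the first direct reading at this position. At this dose, the plain phenyl shows no more effect than 3-methoxyphenyl, so removing methoxy does not reveal activity. With both compounds showing no effect, the step cannot show whether methoxy helps or harms, and nothing measured offers an explanation. Still open, as far as these compounds go, is whether an amine or a longer chain such as butoxy at this carbon would produce any effect. Other doses and times also remain open.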